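The compounds below may be only part of what the source reports. "The series", "measured", "known", "first", "only" and "open" are said of these compounds alone.

Measured compounds:
- compound 1, `CCn1c(C(=O)NCCN)ccc1C(CC)(CC)c1ccc(OCC(O)C(C)(C)C)c(C)c1`, giving 10 nM in an assay on HL-60 cells for agonist activity at vitamin D3 receptor (Homo sapiens), read by microscopy, with a stated time of 96 h; on this read-out higher numbers stand for an effect only at larger amounts of compound and lower numbers for an effect already at smaller amounts
- compound 2, `C=CCN(C)C(=O)c1ccc(C(CC)(CC)c2ccc(OCC(O)C(C)(C)C)c(C)c2)n1CC`, giving 3950 nM in this assay
- compound 3, `CCn1c(C(=O)N(C)CC(=O)O)ccc1C(CC)(CC)c1ccc(OCC(O)C(C)(C)C)c(C)c1`, giving 740 nM in this assay

Compound 3 stands second highest of the three numbers: below compound 2 and far above compound 1, as the steps of a 5.3-fold lower number from compound 2 to compound 3 (0.73 log units; beyond the scatter) and a 74-fold higher number from compound 1 to compound 3 (1.87 log units; beyond the scatter) show. Compound 4, `CCOC(=O)c1ccc(OC(=O)c2ccc(C(CC)(CC)c3ccc(OCC(O)C(C)(C)C)c(C)c3)n2CC)cc1`, has not yet been measured. It differs from compound 3 in one place, (4-(ethoxycarbonyl)phenoxy in place of (carboxymethyl)(methyl)amino on a carbonyl carbon), so that the amide of compound 3 becomes an ester of a substituted phenol.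

Within the data shown here, the steps that bear on this position are a 400-fold higher number from compound 1 to compound 2 (2.60 log units; beyond the scatter) and a 74-fold higher number from compound 1 to compound 3 (1.87 log units; beyond the scatter), both large, and a 5.3-fold lower number from compound 2 to compound 3 (0.73 log units; beyond the scatter), modest. All three show that the group on this carbonyl carbon shifts the numbers in this assay widely, and that the one amide without a hydrogen-bond donor, compound 2, sits highest. Among the measured compounds shown here, no measured step exchanges an amide for an ester, so the direction for compound 4 rests on that analogy alone. Compound 4 is therefore expected to give 2500 nM in this assay, between 300 nM and 20000 nM, an estimated step of a 3.4-fold higher number from compound 3 to compound 4 (0.53 log units; beyond the scatter).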

Compound 4, half-maximal effective concentration: > 50000 nM
Compound 4 ended at the assay's limit (the forecaster's own chance of this, stated with the estimate: 20%); middle value at least 20-fold (1.30 log units) away from the limit.
By their numbers in this assay, from the lowest: compound 1; then compound 3; then compound 2. At a limit, above all of these: compound 4.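

The value of compound 4 is a limit of the assay and not a number: the limit of > 50000 nM in this assay, at which 1 of the 4 values shown sits. Compound 4 is the only ester on this carbonyl carbon among the compounds shown, and its number lies past those of all three amides, with an at least 67-fold higher number from compound 3 to compound 4 (1.82 log units; beyond the scatter), an at least 12-fold higher number from compound 2 to compound 4 (1.10 log units; beyond the scatter) and an at least 5000-fold higher number from compound 1 to compound 4 (3.69 log units; beyond the scatter). Even the amide with the highest number is passed, so at this position the 4-(ethoxycarbonyl)phenoxy group goes further up than the spread among the amides had shown.

Whether the ester link or the aromatic ring of the entering group accounts for this stays open: an ethyl ester on the same carbonyl carbon, or a phenylamino group there, would separate the two. Also open, from the compounds shown here alone, is how a longer chain ending in an amine would compare with the (2-aminoethyl)amino group of compound 1.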